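Hydroxyphenyl in place of methylphenyl on a boron-bearing chalcone

The source may hold more compounds than are shown below. What is called first, only, known or untested is meant among the compounds shown, and "the series" means these compounds.

Measured so far in a toxicity assay on WI-38 cells (Homo sapiens) for cytotoxicity, read by MTT assay, with a stated time of 48 h; on this read-out lower numbers stand for stronger inhibition and higher numbers for weaker inhibition:
compound 1 `O=C(/C=C/c1ccc2c(c1)B(O)OC2)c1ccco1` gives 59000 nM
compound 2 `Cc1ccc(C(=O)/C=C/c2ccc3c(c2)B(O)OC3)cc1` gives 22200 nM
compound 3 `O=C(/C=C/c1ccc2c(c1)B(O)OC2)c1ccc(OCc2ccccc2)cc1` gives > 100000 nM, which is a limit of this assay rather than a number

Among the two numbers, compound 2 stands lowest; the nearest is compound 1, and a 2.7-fold lower number from compound 1 to compound 2 (0.42 log units; beyond the scatter). For compound 3 only a limit is known (the limit of > 100000 nM in this assay, at which 1 of the 3 values shown sits).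

The compound still to be measured is compound 4 `O=C(/C=C/c1ccc2c(c1)B(O)OC2)c1cccc(O)c1`. It differs from compound 2 in one place: 3-hydroxyphenyl in place of 4-methylphenyl on a carbonyl carbon.

Within the data shown here, two measured steps touch the same part of the molecule. One is a 2.7-fold lower number from compound 1 to compound 2 (0.42 log units; beyond the scatter), where a furan-2-yl became a 4-methylphenyl. The other is an at least 4.5-fold higher number from compound 2 to compound 3 (0.65 log units; beyond the scatter), where the methyl on that ring gave way to a benzyloxy. Both changes at this site moved the number beyond the scatter, in opposite directions. Replacing the 4-methylphenyl by a 3-hydroxyphenyl is a change of similar scale, so a step beyond the scatter in this assay is expected, most likely upward, though a modest one.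

For compound 4 the estimate is 45000 nM, within a range from 15000 nM to 130000 nM. This expected result amounts to a 2.0-fold higher number from compound 2 to compound 4 (0.31 log units; beyond the scatter).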

Compound 4, half-maximal inhibitory concentration: 26400 nM
Compound 4: middle estimate off by 1.7-fold (0.23 log units), on the high side; measured number inside the range.
By their numbers in this assay, from the lowest: compounds 2 and 4 (each within the scatter of the next); then compound 1. At a limit, above all of these: compound 3.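

In this assay, placing a 3-hydroxyphenyl where a 4-methylphenyl stood on the carbonyl carbon gives a 1.2-fold higher number from compound 2 to compound 4 (0.08 log units; within the scatter). Among these compounds, this is the first change at this site that leaves the number within the scatter, even though the entering ring carries 1 hydrogen-bond donor and 1 hydrogen-bond acceptor and the leaving ring carries 0 of each, so this difference in counts brings no readable change here. The other new comparison, a 2.2-fold lower number from compound 1 to compound 4 (0.35 log units; beyond the scatter), sits alongside a 2.7-fold lower number from compound 1 to compound 2 (0.42 log units; beyond the scatter), so two different phenyl groups in place of furan-2-yl both lower the number, while compound 3, which also carries a phenyl group at this site, goes against that pattern.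

Compound 3 is known only as a limit, which leaves the full size of its step unknown: the limit of > 100000 nM in this assay, at which 1 of the 4 values shown sits.

Going by these compounds, how an amine, a carboxylic acid or a longer alkyl chain on this phenyl ring would read in this assay remains open, as does the question of whether any such group could lower the number further than the methyl and hydroxyl groups do.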